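Removing the methoxy group from an indole-based growth inhibitor

The source may hold more compounds than are shown below. What is called first, only, known or untested is meant among the compounds shown, and "the series" means these compounds.

Of the compounds shown here, two have been measured in a functional assay on MDA-MB-468 cells (Homo sapiens) for inhibition, read by sulforhodamine B assay, with a stated time of 48 h; a higher number here means a weaker inhibitor of growth, a lower number a stronger inhibitor of growth. Compound 1, with the structure `CC(=O)/C(=C\c1c(-c2ccccc2)[nH]c2ccccc12)S(=O)(=O)c1ccccc1`, gives 1700 nM in this assay. Compound 2, with the structure `COc1ccc2[nH]c(-c3ccccc3)c(/C=C(\C#N)S(=O)(=O)c3ccccc3)c2c1`, gives 4200 nM, the highest of the two numbers; its nearest neighbour is compound 1, whose number is lower by a margin beyond the usual scatter. Compound 1 and compound 2 differ in more than one place, so their two values can only be reported side by side.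

The step under consideration leads from compound 2 to compound 3, the structure `N#C/C(=C\c1c(-c2ccccc2)[nH]c2ccccc12)S(=O)(=O)c1ccccc1`, which has not yet been measured. The change is hydrogen in place of methoxy on an aromatic carbon. For the measured compounds named here, no pair of measured compounds differs by this single change, so the data give no direct guide to its size or direction. The expectation is therefore a step from compound 2 to compound 3 of about a 1.4-fold lower number from compound 2 to compound 3 (0.15 log units; within the scatter), that is, little beyond the scatter in either direction. Compound 3 is estimated to give 3000 nM, with a range from 1000 nM to 9000 nM.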

Compound 3, concentration for 50% growth inhibition: 1900 nM
Compound 3: middle estimate off by 1.6-fold (0.20 log units), on the high side; the measured number falls inside the stated range.
By their numbers in this assay, from the lowest: compounds 1 and 3 (each within the scatter of the next); then compound 2.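

In this assay, the step of a 2.2-fold lower number from compound 2 to compound 3 (0.34 log units; beyond the scatter) is modest but beyond the scatter, so this place on the six-membered aromatic ring does respond to the change: with hydrogen in place of methoxy, the compound is the stronger inhibitor of growth. Removing the methoxy group also leaves compound 3 differing from compound 1 in one place only, which makes a comparison possible that the first two compounds did not allow, and the step of a 1.1-fold higher number from compound 1 to compound 3 (0.05 log units; within the scatter) lies within the scatter, so cyano and acetyl on this chain carbon cannot be told apart in this assay. Nothing shown here gives a reason for either result.

With only methoxy and hydrogen shown at this place on the ring, it remains open how a hydroxyl group, a chlorine atom or an amine there would compare. From the compounds shown here alone, it also remains open whether the step seen with the cyano group would hold with an acetyl group on the chain, or whether a longer alkoxy chain in place of methoxy would move the number further.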